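Chalcone-linked series: aryl ketone variation

This account rests on a few compounds, and the source may have more. Where it says the series, first, only, none or still open, it means among the compounds named here.

Measured compounds in a functional assay on MDA-MB-231 cells (Homo sapiens) for antiproliferative activity, read by MTT assay, with a stated time of 24 h; on this read-out lower numbers stand for stronger inhibition and higher numbers for weaker inhibition:
compound 1 `COc1ccc(-c2cc(/C=C/C(=O)c3ccc(C)cc3)nc3cc(-c4ccccc4)nn23)cc1OC`, 19800 nM
compound 2 `COc1ccc(-c2cc(/C=C/C(=O)c3ccc(OC)c(OC)c3)nc3cc(-c4ccccc4)nn23)cc1`, 8700 nM
compound 3 `COc1ccc(-c2cc(/C=C/C(=O)c3ccc(C)c(C)c3)nc3cc(-c4ccccc4)nn23)cc1OC`, 11500 nM

Compound 3 stands second highest of the three numbers in this assay; its nearest neighbour is compound 2 and its furthest is compound 1, both within the scatter of it. Among the measured compounds shown here, the only measured single step, a 1.7-fold lower number from compound 1 to compound 3 (0.24 log units; within the scatter), is within the scatter, so the ring attached to the carbonyl has so far moved the number little.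

Compound 4 `COc1ccc(C(=O)/C=C/c2cc(-c3ccc(OC)c(OC)c3)n3nc(-c4ccccc4)cc3n2)cc1OC` differs from compound 3 by 3,4-dimethoxyphenyl in place of 3,4-dimethylphenyl on a carbonyl carbon. For the measured compounds named here, no measured step covers this exact exchange. Compound 2, which carries the same 3,4-dimethoxyphenyl on the carbonyl carbon but a different ring on the shared core, gives 8700 nM, close to compound 3. For compound 4 the step of a 1.4-fold lower number from compound 3 to compound 4 (0.16 log units; within the scatter) is therefore expected to be small, toward a somewhat lower number but not beyond the scatter. Compound 4 is estimated at 8000 nM, with a range from 3500 nM to 18000 nM.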

Compound 4, half-maximal inhibitory concentration: 2600 nM
For compound 4 the middle estimate is 3.1-fold (0.49 log units) above the measured one, and the stated range ends above it.
By their numbers in this assay, from the lowest: compound 4; then compounds 2, 3 and 1 (each within the scatter of the next, the first and the last beyond it).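

In this assay, 3,4-dimethoxyphenyl in place of 3,4-dimethylphenyl on a carbonyl carbon gives a 4.4-fold lower number from compound 3 to compound 4 (0.65 log units; beyond the scatter), and in place of 4-methylphenyl it gives a 7.6-fold lower number from compound 1 to compound 4 (0.88 log units; beyond the scatter), so this position can move the number beyond the scatter, which the earlier methyl step did not show. With 3,4-dimethoxyphenyl held on the carbonyl carbon, an added methoxy group on the shared core gives a 3.3-fold lower number from compound 2 to compound 4 (0.52 log units; beyond the scatter), so a second place on the shared core also moves the number. No available evidence bears on the reason for these steps.

Open, as far as these compounds go, is how a ring carrying an amine or a carboxylic acid on the carbonyl carbon would compare with 3,4-dimethoxyphenyl. Also open, from the compounds shown here alone, is whether the exchange of 3,4-dimethylphenyl for 3,4-dimethoxyphenyl gives a similar step with another ring on the shared core.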